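A few compounds are considered here, and "the series" means these few. Any claim that something is new, unique, unknown or untested is made for them only; others in the source may bear on it.

Measured compounds in an ADME assay on L929 cells (Mus musculus) for cytotoxicity, read by resazurin assay, with a stated time of 72 h; on this read-out higher numbers stand for weaker inhibition and lower numbers for stronger inhibition:
Compound 1 `OB1OCc2ccc(-n3cc(Sc4ccc(Cl)c(Cl)c4)c4ccccc43)cc21` gives > 10 ug/mL, a limit of the assay rather than a number.
Compound 2 `OB1OCc2ccc(-n3cccc3Sc3ccccc3Cl)cc21` gives > 10 ug/mL, again a limit.
Compound 3 `Cc1cccc(C(=O)c2ccn(-c3ccc4c(c3)B(O)OC4)c2)c1` gives > 10 ug/mL, also a limit.

Compound 3 therefore stands nowhere in particular among these three: its result is only a limit, and the same holds for compound 1 and compound 2, so that the whole set rests on (the limit of > 10 ug/mL in this assay, at which 3 of the 3 values shown sit). Among the compounds with values here, no ordering among them can be read from this, and no measured step between any pair exists.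

The unmeasured compound 4 `NCc1ccc(C(=O)c2ccn(-c3ccc4c(c3)B(O)OC4)c2)cc1` differs from compound 3 in one place: 4-(aminomethyl)phenyl in place of 3-methylphenyl on a carbonyl carbon. Within the data shown here, with no measured step to lean on, and with every measured value sitting at the limit, the expectation for this change in this assay is no step beyond the usual scatter, in neither direction; the expected step that the limit leaves unreadable from compound 3 to compound 4 is thus held close to nothing.

Compound 4 is accordingly estimated at 15 ug/mL, with a range from 7 ug/mL to 40 ug/mL, and the most likely outcome is that the assay again reports only a limit.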

Compound 4, half-maximal inhibitory concentration: > 10 ug/mL
Compound 4 ended at the assay's limit; the forecaster's own chance of this, stated with the estimate: 80%; the middle value is on the limit's open side.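

In this assay compound 4 gives > 10 ug/mL, which is a limit of the assay. No step from compound 3 to compound 4 can be read, since the whole set rests on limits: the limit of > 10 ug/mL in this assay, at which 4 of the 4 values shown sit.

The compounds shown leave open how the four compare with one another and at what concentration any of them would reach half-maximal inhibition.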